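Methyl for trifluoromethyl on the shared core

The source may report more compounds than this note shows. Statements on the series, on what has been measured and on what is new or still open speak of the compounds shown alone.

Measured compounds:
compound 1 `Cc1nc(N(C)C(=O)NC(=O)c2ccc(Cl)cc2Cl)sc1C(=O)N/N=C/c1ccc(C(F)(F)F)cc1` — 24.5 ug/mL
compound 2 `Cc1nc(N(C)C(=O)NC(=O)c2c(F)cccc2F)sc1C(=O)N/N=C/c1ccccc1C(F)(F)F` — 7.34 ug/mL
compound 3 `CN(C(=O)NC(=O)c1c(F)cccc1F)c1nc(C(F)(F)F)c(C(=O)N/N=C/c2ccc(C(F)(F)F)cc2)s1` — 35.3 ug/mL

In a functional assay on MCF7 cells (Homo sapiens) for inhibition, read by MTT assay, with a stated time of 72 h (on this read-out lower numbers stand for stronger inhibition and higher numbers for weaker inhibition), compound 3 gives 35.3 ug/mL, the highest of the three numbers. Compound 1 sits nearest to it with 24.5 ug/mL, a gap within the usual scatter, so no order between compound 3 and compound 1 can be claimed. Compound 2 is furthest with 7.34 ug/mL, a gap beyond the scatter, so compound 2 inhibits more strongly than compound 3 on this read-out.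

Compound 4 `Cc1nc(N(C)C(=O)NC(=O)c2c(F)cccc2F)sc1C(=O)N/N=C/c1ccc(C(F)(F)F)cc1` has not been measured. It differs from compound 3 in one place: methyl in place of trifluoromethyl on an aromatic carbon. Among the measured compounds shown here, compound 1 and compound 2 carry the methyl already, but each also differs from compound 4 elsewhere, so no single step to compound 4 is available from them. The expectation for compound 4 is a lowering of the number, an estimated step of a 2.4-fold lower number from compound 3 to compound 4 (0.37 log units; beyond the scatter), of moderate size and only at the edge of the scatter. Compound 4 is estimated at 15 ug/mL, with a range from 5 ug/mL to 40 ug/mL in this assay.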

Compound 4, half-maximal inhibitory concentration: 30.6 ug/mL
Compound 4: middle estimate off by 2.0-fold (0.31 log units), on the low side; the range from low to high includes it.
By their numbers in this assay, from the lowest: compound 2; then compounds 1, 4 and 3 (each within the scatter of the next).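

In this assay, the step of a 1.2-fold lower number from compound 3 to compound 4 (0.06 log units; within the scatter) shows that, with the rest of the molecule held fixed, no difference can be read between methyl and trifluoromethyl on this aromatic carbon next to the ring nitrogen. Exchanging 2,4-dichlorophenyl for 2,6-difluorophenyl on the carbonyl carbon also leaves no readable difference, with a 1.2-fold higher number from compound 1 to compound 4 (0.10 log units; within the scatter) as the step. Moving to 4-(trifluoromethyl)phenyl in place of 2-(trifluoromethyl)phenyl on the carbon with a double bond to nitrogen gives a 4.2-fold higher number from compound 2 to compound 4 (0.62 log units; beyond the scatter) and is the only one of the three steps beyond the scatter.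

The data at hand give no explanation for any of these steps. Also open, from the compounds shown here alone, is whether an amine or a carboxylic acid on this aromatic carbon would separate from methyl and trifluoromethyl.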